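Capping the ring amine of compound 2

A few compounds are considered here, and "the series" means these few. Any claim that something is new, unique, unknown or untested is made for them only; others in the source may bear on it.

Compound 1, `CNCCCNc1c(C(=O)NCc2ccc(F)cc2)nc(Br)c2cccnc12`: in a functional assay on LNCaP cells (Homo sapiens) for cytotoxicity, read by MTT assay, with a stated time of 72 h (a higher number here means a weaker inhibitor, a lower number a stronger inhibitor), compound 1 gives 8000 nM.
Compound 2, `O=C(NCc1ccc(F)cc1)c1nc(Br)c2cccnc2c1N1CCNCC1`: in this assay compound 2 gives 4500 nM.
Compound 3, `NCCCCCCNc1c(C(=O)NCc2ccc(F)cc2)nc(Br)c2cccnc12`: in this assay compound 3 gives 8000 nM.

Compound 2 is separated from compound 1 by a 1.8-fold lower number from compound 1 to compound 2 (0.25 log units; within the scatter) and from compound 3 by a 1.8-fold higher number from compound 2 to compound 3 (0.25 log units; within the scatter); compound 1 and compound 3 are separated by no change at the digits printed from compound 1 to compound 3 (within the scatter). Among the measured compounds shown here, all three numbers sit within the scatter of one another, so no compound can be called stronger or weaker here.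

Compound 4, `CC(C)(C)OC(=O)N1CCN(c2c(C(=O)NCc3ccc(F)cc3)nc(Br)c3cccnc23)CC1`, differs from compound 2 by tert-butoxycarbonyl in place of hydrogen on an amine nitrogen in a ring. For the measured compounds named here, no measured step caps a ring amine; the steps seen so far replace one amine substituent on the aromatic carbon with another and stay within the scatter. For compound 4 a step of a 1.2-fold higher number from compound 2 to compound 4 (0.09 log units; within the scatter) is expected, with no change beyond the scatter. Compound 4 is estimated at 5500 nM, in the range 2500 nM to 12000 nM.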

Compound 4, half-maximal inhibitory concentration: > 10000 nM
Compound 4: only a limit was reported; the forecaster's own chance of this, stated with the estimate: 5%; at least 1.8-fold (0.25 log units) between middle value and limit.
By their numbers in this assay, from the lowest: compounds 2, 1 and 3 (each within the scatter of the next). At a limit, above all of these: compound 4.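

In this assay compound 4 gives only a limit, > 10000 nM. Tert-butoxycarbonyl on the amine nitrogen in the ring gives an at least 2.2-fold higher number from compound 2 to compound 4 (0.34 log units; beyond the scatter), the only step in this set beyond the scatter; the steps among compound 1, compound 2 and compound 3 all stay within it. On this single pair, the ring nitrogen is a place where a change registers, unlike the amine exchanges on the aromatic carbon.

From the compounds shown here alone, the full size of the step stays open: the limit of > 10000 nM in this assay, at which 1 of the 4 values shown sits. Going by these compounds, whether a smaller group on the same nitrogen, such as methyl or acetyl, also moves the number stays open too.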